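A few compounds are considered here, and "the series" means these few. Any claim that something is new, unique, unknown or untested is made for them only; others in the source may bear on it.

In an ADME assay on microsomes from liver (Homo sapiens) for metabolic stability, read by LC-MS, using NADPH, with a stated time of 60 min, tested at 1 uM (on this read-out higher numbers stand for fast clearance and lower numbers for slow clearance), compound 1 `CS(=O)(=O)NC(=O)c1cc(C2CC2)c(OCC2CCN(Cc3ccc(OC(F)(F)F)cc3)CC2)cc1F` gives 9.9 mL/min/kg, and compound 2 `CS(=O)(=O)NC(=O)c1cc(C2CC2)c(OCC2CCN(Cc3ccc(Cl)cc3)CC2)cc1F` gives 9.9 mL/min/kg, so compound 2 stands level with compound 1. The next structure, compound 3 `CS(=O)(=O)NC(=O)c1cc(C2CC2)c(OCC2CCN(Cc3cc(Cl)cc(Cl)c3)CC2)cc1F`, differs from compound 2 in one place: 3,5-dichlorophenyl in place of 4-chlorophenyl on a saturated chain carbon bound to an amine nitrogen in a ring. Among the measured compounds shown here, the one measured step on this aromatic ring is no change at the digits printed from compound 1 to compound 2 (within the scatter), so no step beyond the scatter is expected here in this assay. The expected size of the new step is a 1.1-fold higher number from compound 2 to compound 3 (0.05 log units; within the scatter). Compound 3 is estimated at 11 mL/min/kg, with an expected range from 6 mL/min/kg to 19 mL/min/kg.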

Compound 3, clearance: 9.7 mL/min/kg
The estimate for compound 3 lay 1.1-fold (0.05 log units) above the measured number; measured number inside the range.
By their numbers in this assay, from the lowest: compounds 3, 1 and 2 (each within the scatter of the next).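

In this assay, the 3,5-dichlorophenyl group in place of 4-chlorophenyl gives a 1.0-fold lower number from compound 2 to compound 3 (0.01 log units; within the scatter), so this position accepts a second chlorine with clearance staying within the scatter. In place of 4-(trifluoromethoxy)phenyl, the same group gives a 1.0-fold lower number from compound 1 to compound 3 (0.01 log units; within the scatter), so all three substituted phenyl rings sit within the scatter of one another. No measurement here offers a cause for this flat result.

Still open, as far as these compounds go, is whether a different kind of group on this ring, such as an amine or a carboxylic acid, would give a step beyond the scatter. A pyridine in place of the phenyl ring is equally untested by the compounds shown.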